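From 3,5-dimethylphenyl to 4-methylphenyl on a sulfur

The compounds below may be only part of what the source reports. "The series", "measured", "known", "first", "only" and "open" are said of these compounds alone.

- Compound 1 `COc1ccc(SCc2ccc(/C=C/C(=O)Nc3ccccc3N)cc2)cc1OC`: 65.5%
- Compound 2 `Cc1cc(C)cc(SCc2ccc(/C=C/C(=O)Nc3ccccc3N)cc2)c1`: 46.1%
- Compound 3 `Nc1ccccc1NC(=O)/C=C/c1ccc(CSc2cccc(F)c2)cc1`: 50.7%

In a functional assay on A549 cells (Homo sapiens) for inhibition, read by CCK-8 assay, with a stated time of 72 h, tested at 2 uM (a lower number here means less inhibition of growth, a higher number more inhibition of growth at the concentration tested), compound 2 gives 46.1%. Its closest neighbour in this small set shows the step of a number 4.6 percentage points higher from compound 2 to compound 3 (within the scatter), so those two cannot be told apart. Only the compound carrying 3,4-dimethoxyphenyl stands clear of it, with the step of a number 19.4 percentage points lower from compound 1 to compound 2 (beyond the scatter).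

Compound 4 `Cc1ccc(SCc2ccc(/C=C/C(=O)Nc3ccccc3N)cc2)cc1` has not yet been measured. It carries 4-methylphenyl in place of 3,5-dimethylphenyl on a sulfur.

Three measured swaps at this same place bear on the change. The two clear ones, a number 19.4 percentage points lower from compound 1 to compound 2 (beyond the scatter) and a number 14.8 percentage points lower from compound 1 to compound 3 (beyond the scatter), both remove 3,4-dimethoxyphenyl, a group that plays no part here. The swap that leaves it out of play, a number 4.6 percentage points higher from compound 2 to compound 3 (within the scatter), stayed small, so no step beyond the scatter is expected, and no firm direction either.

The expected step is a number 3.9 percentage points higher from compound 2 to compound 4 (within the scatter).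

For compound 4 the estimated value is 50%, with an expected range of 38% to 62%.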

Compound 4, percent growth inhibition at one concentration: 43.4%
Beside the measured number, compound 4's estimate is 6.6 percentage points above it, within the range that was stated.
By their numbers in this assay, from the lowest: compounds 4, 2 and 3 (each within the scatter of the next); then compound 1.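

In this assay, swapping 3,5-dimethylphenyl for 4-methylphenyl on the sulfur gives a number 2.7 percentage points lower from compound 2 to compound 4 (within the scatter), so this change makes no readable difference. The comparison with 3-fluorophenyl gives a number 7.3 percentage points lower from compound 3 to compound 4 (within the scatter), while the comparison with 3,4-dimethoxyphenyl gives a number 22.1 percentage points lower from compound 1 to compound 4 (beyond the scatter), so among these four compounds, 3,4-dimethoxyphenyl alone stands clear of the three other groups, which cannot be told apart. No measurement available here explains why this group stands apart.

Going by these compounds, it remains open whether both methoxy groups are needed, or whether a single one, as in 4-methoxyphenyl, would keep compound 1's higher number. Also open, on these data alone, is whether the effect needs a methoxy group at all, or whether a hydroxyl group or an amine on the same ring would match it.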